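The compounds below may be only part of what the source reports. "The series", "measured", "known", "first", "only" and "open" are said of these compounds alone.

Compound 1 `COc1cc(C(=O)O)ccc1OCCCCOc1ccc(C(=O)CC(C)C)c(O)c1C` and compound 2 `CCCC(=O)c1ccc(OCCCCOc2cc(C(=O)O)ccc2OC)c(C)c1O` are built on related cores; the difference between the two cores is not broken down here. In an assay on HEK293 cells for positive allosteric modulation of metabotropic glutamate receptor 3 (Rattus norvegicus), read by thallium flux, with a stated time of 2.5 min (on this read-out higher numbers stand for larger maximal responses and lower numbers for smaller maximal responses), compound 1 gives 73.9%, and compound 2 gives 64.2%; these two values lie within the scatter of each other. Compound 3 `COc1ccc(C(=O)O)cc1OCCCCOc1ccc(C(=O)CC(C)C)c(O)c1C` differs from compound 2 by methyl in place of hydrogen on a saturated chain carbon bound to two saturated chain carbons. In this assay compound 3 gives 100%, a step of a number 35.8 percentage points higher from compound 2 to compound 3 (beyond the scatter). Compound 4 `COc1cc(C(=O)O)ccc1OCCCCOc1ccc(C(=O)CC(C)(C)C)c(O)c1C` differs from compound 1 by methyl in place of hydrogen on a saturated chain carbon bound to three saturated chain carbons. This is the same kind of change, though the place differs: a saturated chain carbon bound to three saturated chain carbons rather than two. For compound 4 a step of a number 11.1 percentage points higher from compound 1 to compound 4 (beyond the scatter) is expected, smaller than the earlier one because the step of a number 35.8 percentage points higher from compound 2 to compound 3 (beyond the scatter) started from a lower value and compound 1 already stands at 73.9%. Compound 4 is therefore estimated at 85%, between 62% and 100%.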

Compound 4, largest response reached (reported as percent of maximum), in percent of the reference or control that the assay uses: 109%
Estimate against measurement, compound 4: 24 percentage points below; measured number above the stated range.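

The isobutyl to neopentyl change gives a number 35.1 percentage points higher from compound 1 to compound 4 (beyond the scatter), read in this assay. Set beside the earlier methyl step, the size of the gain carries over from one core to the other: the same change on two cores in this assay, a number 35.8 percentage points higher (beyond the scatter) from compound 2 to compound 3 and a number 35.1 percentage points higher (beyond the scatter) from compound 1 to compound 4, 0.7 percentage points apart, within the scatter of two such steps This rests on only two pairs, with the methyl placed on differently substituted chain carbons, so it does not show that the step would hold on a further core, nor does it explain why the response rises.

The compounds shown leave open whether a longer chain or a cyclopropyl ring at this end of the ketone would raise the response further or leave it level. They also leave open how an amide in place of the carboxylic acid would behave.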